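Fluoro in Place of Difluoromethoxy: Compound 1 to Compound 4

This account rests on a few compounds, and the source may have more. Where it says the series, first, only, none or still open, it means among the compounds named here.

Measured compounds:
compound 1, `FC(F)Oc1ccccc1C1Cc2nccn2C1`: "not determined" (no result reported)
compound 2, `COc1ccccc1C1CCc2nc[nH]c2C1`: > 10000 nM
compound 3, `COc1cccc(C2Cc3nccn3C2)c1`: > 10000 nM

In a functional assay on CHO cells for agonist activity at Alpha-1B adrenergic receptor (Homo sapiens), read by FLIPR and calcium flux (a lower number here means that less compound is needed, a higher number that more compound is needed for the effect), compound 1 stands without a number; its entry reads "not determined" (no result reported). Compound 2 is reported only as a limit of the assay, > 10000 nM. Compound 3 likewise reaches only a limit, > 10000 nM. Where compound 1 stands among the numbers therefore cannot be said: of the three values shown, two sit at the limit of > 10000 nM in this assay, at which 2 of the 3 values shown sit, and the third is absent.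

Compound 4, `Fc1ccccc1C1Cc2nccn2C1`, differs from compound 1 in one place: fluoro in place of difluoromethoxy on an aromatic carbon. Among the measured compounds shown here, no step between two measured compounds is recorded, so the size of the change in this assay that this replacement brings cannot be read from the data. With nothing to anchor it, the account expects no step beyond the usual scatter from compound 1, whatever number compound 1 would have given.

Taking the two limits as the only guide, compound 4 is estimated to give about 15000 nM in this assay, with a range expected from 3000 nM to 60000 nM.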

Compound 4, half-maximal effective concentration: 1770 nM
Compound 4: middle estimate off by 8.5-fold (0.93 log units), on the high side; the measured number lies below the stated range.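

Among the compounds shown here, no step from compound 1 to compound 4 can be read in this assay: compound 1 carries no number there. The compounds shown leave open what fluoro in place of difluoromethoxy does to the read-out, and how far compound 4 stands from the compounds reported only as a limit: the limit of > 10000 nM in this assay, at which 2 of the 4 values shown sit.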